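The compounds below may be only part of what the source reports. "The series", "measured", "known", "first", "only" and "open" are said of these compounds alone.

Compound 1, `CCCCNC(=O)[C@H]1OC(n2cnc3c(N)ncnc32)[C@H](O)[C@@H]1O`, carries a butyl chain on its amide nitrogen. In an assay on cell membranes for binding affinity to 2-oxoglutarate receptor 1 (Rattus norvegicus), read by radioligand binding (a lower number here means a stronger inhibitor, a higher number a weaker inhibitor), compound 1 gives 17 nM. Its companion compound 2, `CCCCCNC(=O)[C@H]1O[C@@H](n2cnc3c(N)ncnc32)[C@H](O)[C@@H]1O`, has a pentyl chain in the same position and gives 12 nM in this assay. The two numbers lie within the usual scatter of each other, so nothing separates compound 1 from compound 2 on these two values alone; they simply sit close together.

Compound 3, `CCCCCCNC(=O)[C@H]1OC(n2cnc3c(N)ncnc32)[C@H](O)[C@@H]1O`, extends the chain once more. It differs from compound 1 by ethyl in place of hydrogen on a saturated chain carbon, four bonds along the chain from an amide-type nitrogen. Among the compounds with values here, only two measured compounds are available, and no step between them is large enough to count, so the expectation for this change rests on thin ground: lengthening the chain has so far moved the number little.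

The step from compound 1 to compound 3 is therefore expected to be small, most likely toward a lower number but not clearly beyond the scatter, a 1.7-fold lower number from compound 1 to compound 3 (0.23 log units; within the scatter). For compound 3 in this assay the estimate is 10 nM, with a range from 4 nM to 25 nM.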

Compound 3, inhibition constant: 19 nM
Compound 3: middle estimate off by 1.9-fold (0.28 log units), on the low side, and the stated range covers the measured number.
By their numbers in this assay, from the lowest: compounds 2, 1 and 3 (each within the scatter of the next).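

Ethyl in place of hydrogen on a saturated chain carbon, four bonds along the chain from an amide-type nitrogen, gives a 1.1-fold higher number from compound 1 to compound 3 (0.05 log units; within the scatter) in this assay. Within the data shown here, this is the first step at this position that can be read directly between two compounds with the same change in one place, and it shows that these two added carbons leave compound 3 indistinguishable from compound 1 in this assay, so the position accepts the extra length with no gain or loss that can be told from the scatter. No supporting measurement is available to explain why the added ethyl makes no detectable difference here.

The compounds shown cover only plain saturated chains, so a single flat step says nothing about how far this tolerance extends, and a longer chain might or might not behave the same way. Also open, on these data alone, is whether a group of a different kind in this place, such as an amine, a carboxylic acid or a phenyl ring, would move the number beyond the scatter in this assay.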